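The source may hold more compounds than are shown below. What is called first, only, known or untested is meant among the compounds shown, and "the series" means these compounds.

Three compounds sharing one core, the structures of which differ only in how their stereocentres are drawn, have been tested in an assay on isolated protein for inhibition of cytosolic endo-beta-N-acetylglucosaminidase (Homo sapiens), tested at 1000 uM; on this read-out lower numbers stand for less inhibition and higher numbers for more inhibition at the one concentration tested (going by the name of the read-out). Compound 1 `O=C(O)[C@H]1NC[C@H](O)[C@@H](O)[C@H]1O` gives 2.6% in this assay. Compound 2 `O=C(O)[C@@H]1NC[C@@H](O)[C@@H](O)[C@@H]1O` gives 2.1% in this assay. Compound 3 `O=C(O)[C@@H]1NC[C@H](O)[C@@H](O)[C@@H]1O` gives 5.4% in this assay. The step of a number 0.5 percentage points lower from compound 1 to compound 2 (within the scatter) lies within the scatter, the step of a number 2.8 percentage points higher from compound 1 to compound 3 (within the scatter) lies within the scatter, and the step of a number 3.3 percentage points higher from compound 2 to compound 3 (within the scatter) lies within the scatter, so compound 3 stands with the other two inside a single band of near-zero numbers. Compound 4 `O=C(O)[C@@H]1NC[C@H](O)[C@@H](O)[C@H]1O` remains to be measured in this assay. the two compounds have the same atoms and bonds and differ only in configuration as drawn: 1 of 4 stereo elements differ; a stereocentre at a saturated ring carbon is drawn R in compound 3 and S in compound 4 Each measured step was a change of configuration alone the fact that compounds 1 and 2 differ only in the configuration as drawn the fact that compounds 1 and 3 differ only in the configuration as drawn (the fact that compounds 2 and 3 differ only in the configuration as drawn), and the nearest of them, a number 3.3 percentage points higher from compound 2 to compound 3 (within the scatter), also turned one stereocentre and moved the number only within the scatter. The step of a number 1.4 percentage points lower from compound 3 to compound 4 (within the scatter) is therefore expected to be no larger than the scatter and without a clear direction. Compound 4 is estimated to give 4% in this assay, with a range from 0% to 12%.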

Compound 4, a percentage reported as inhibition, at one concentration (the size of the read-out at that concentration, not a potency): 42%
Compound 4: the middle estimate sits 38 percentage points below what was measured; measured number outside the range, above it.
By their numbers in this assay, from the lowest: compounds 2, 1 and 3 (each within the scatter of the next); then compound 4.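

In this assay, among the compounds shown here, the change of a single stereocentre at a saturated ring carbon, which had moved the number only within the scatter among the earlier compounds, now gives the step of a number 36.6 percentage points higher from compound 3 to compound 4 (beyond the scatter), and a change at a different single stereocentre gives the step of a number 39.4 percentage points higher from compound 1 to compound 4 (beyond the scatter). The step of a number 39.9 percentage points higher from compound 2 to compound 4 (beyond the scatter), which spans two stereocentres, is of similar size, so among these compounds only the arrangement drawn in compound 4 stands clear of the near-zero band. No atom or bond is involved in the single-centre change from the nearest neighbour, so the gain goes with configuration alone: the fact that compounds 3 and 4 differ only in the configuration as drawn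

The single concentration gives no potency for compound 4. Going by these compounds, whether this arrangement would keep its inhibition with a methyl ester in place of the carboxylic acid also stays open.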